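A few compounds are considered here, and "the series" means these few. Any claim that something is new, unique, unknown or untested is made for them only; others in the source may bear on it.

In a functional assay on MCF7 cells (Homo sapiens) for inhibition, read by sulforhodamine B assay (on this read-out higher numbers stand for weaker inhibition and lower numbers for stronger inhibition), compound 1 `O=C1C=C(N2CCC2)C(=O)c2c1nc1n2[C@H]2OC[C@@H](O)[C@H]2OC1`, with azetidin-1-yl on the shared core, reads > 16000 nM, which is a limit and not a number. Compound 2 `O=C1C(Nc2ccc(Br)cc2)=CC(=O)c2c1nc1n2[C@H]2OC[C@@H](O)[C@H]2OC1` gives 4330 nM, and compound 3 `CCc1ccc(NC2=CC(=O)c3nc4n(c3C2=O)[C@H]2OC[C@@H](O)[C@H]2OC4)cc1` gives 960 nM, the lower of these two numbers. Compound 4 `O=C1C=C(Nc2ccc(C(F)(F)F)cc2)C(=O)c2c1nc1n2[C@H]2OC[C@@H](O)[C@H]2OC1` carries trifluoromethyl in place of ethyl on an aromatic carbon of compound 3, para to a large group: trifluoromethyl in place of ethyl on an aromatic carbon. Among the compounds with values here, the one measured step that bears on this, an at least 16-fold lower number from compound 1 to compound 3 (1.22 log units; beyond the scatter), is large, but it exchanges the whole azetidin-1-yl group for (4-ethylphenyl)amino, so it says little about a change on the ring alone. The expected size is therefore modest, with a 1.4-fold higher number from compound 3 to compound 4 (0.13 log units; within the scatter), not beyond the scatter. For compound 4 the estimated value is 1300 nM, ranging from 450 nM to 4500 nM.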

Compound 4, half-maximal inhibitory concentration: > 4000 nM
Compound 4: no number, only a limit; the forecaster's own chance of this, stated with the estimate: 5%; middle value at least 3.0-fold (0.48 log units) from the limit.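

Replacing ethyl with trifluoromethyl on an aromatic carbon, para to a large group, gives an at least 4.1-fold higher number from compound 3 to compound 4 (0.61 log units; beyond the scatter), so inhibition weakens. Within the data shown here, this is the first step here that alters only a group on the aromatic ring rather than the whole group on the shared core, and it shows that this position does not tolerate every small group equally. Compound 4 gives > 4000 nM, which is a limit and not a number.

On these data alone, how much weaker compound 4 truly is stays open. Also open, as far as these compounds go, is how a methoxy group, an amine or a longer chain such as butyl would read at this position.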